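Cytotoxicity of a Urea Series: From Acid to Amide

This account rests on a few compounds, and the source may have more. Where it says the series, first, only, none or still open, it means among the compounds named here.

Compound 1 `Cc1cc(NC(=O)Nc2ccc(C(=O)O)cc2)c2ccccc2n1` was tested in an ADME assay on BJ cells (Homo sapiens) for cytotoxicity, with a stated time of 72 h; on this read-out lower numbers stand for an effect already at smaller amounts and higher numbers for an effect only at larger amounts of compound. In this assay compound 1 gives > 25000 nM, which is a limit of the assay and not a number. Compound 2 `Cc1cc(NC(=O)Nc2cnc3ccccc3c2)c2ccccc2n1` in this assay gives > 25000 nM, likewise a limit. Compound 3 `Cc1cc(NC(=O)Nc2ccc(C(=O)O)c(O)c2)c2ccccc2n1` in this assay gives > 25000 nM, again a limit. Going by the values given here, the one step between measured compounds that differ in one place, a step that the two limits leave unreadable from compound 1 to compound 3, cannot be read, since both of its ends sit at the limit. All three measured values share (the limit of > 25000 nM in this assay, at which 3 of the 3 values shown sit). Compound 4 `Cc1cc(NC(=O)Nc2ccc(C(N)=O)cc2)c2ccccc2n1` has not yet been measured in this assay. It differs from compound 1 by amino in place of hydroxy on a carbonyl carbon. Among the compounds with values here, no measured step bears directly on this change, and the only step in hand is unreadable, so no size of step beyond the scatter is expected in either direction. Compound 4 is therefore expected to give 30000 nM, in a range from 10000 nM to 100000 nM, most probably reported once more as a limit. The step is estimated as a step that the limit leaves unreadable from compound 1 to compound 4.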

Compound 4, half-maximal effective concentration: > 25000 nM
Compound 4 ended at the assay's limit (the forecaster's own chance of this, stated with the estimate: 85%); the middle value does not contradict the limit.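

Compound 1 and compound 4 give no readable step, and the change from carboxy to carbamoyl has no measurable size, as all values rest at one limit: the limit of > 25000 nM in this assay, at which 4 of the 4 values shown sit. What stays open is the concentration at which any of these compounds would affect this assay at all.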